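A few compounds are considered here, and "the series" means these few. Any claim that something is new, unique, unknown or untested is made for them only; others in the source may bear on it.

The series shares one core, carried on a thioether chain to an amide whose aryl group varies. Going by the values given here, compound 1 `Cn1c(Cc2nn(C)c(=O)c3ccccc23)nnc1SCCCCCCCC(=O)Nc1ccc(Cl)cc1Cl` stands lowest of the two numbers measured so far: in an assay on cells for inhibition of IL15-IL15 receptor (Homo sapiens), read by AlphaScreen, with stated times of 30 min and 1 h (a lower number here means a stronger inhibitor, a higher number a weaker inhibitor), compound 1 gives 153000 nM. Compound 2 `Cn1c(Cc2nn(C)c(=O)c3ccccc23)nnc1SCC(=O)Nc1ccc(Cl)cc1Cl` carries the same aryl amide on a far shorter chain, and in this assay compound 2 gives 9110000 nM, a gap beyond the scatter, so compound 1 stands clearly ahead of compound 2 on the numbers shown. Compound 3 `Cc1ccc(NC(=O)CCCCCCCSc2nnc(Cc3nn(C)c(=O)c4ccccc34)n2C)c(Cl)c1` keeps the long chain of compound 1 and changes only the aryl group: methyl in place of chloro on an aromatic carbon. Among the compounds with values here, no measured pair in this set isolates such a change on the aryl ring, so nothing here tells how it should read. The chloro and the methyl match in heavy-atom count and in the absence of donors, acceptors and charge; on that footing a step within the scatter is expected, with at most a slight lean toward a weaker inhibitor. The estimate for compound 3 in this assay is therefore 200000 nM, with a range from 60000 nM to 650000 nM, which means an expected step of a 1.3-fold higher number from compound 1 to compound 3 (0.12 log units; within the scatter).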

Compound 3, half-maximal inhibitory concentration: 76000 nM
Beside the measured number, compound 3's estimate is 2.6-fold (0.42 log units) above it; measured number inside the range.
By their numbers in this assay, from the lowest: compounds 3 and 1 (each within the scatter of the next); then compound 2.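

In this assay, going by these compounds alone, the exchange of 2,4-dichlorophenyl for 2-chloro-4-methylphenyl on the long chain gives a 2.0-fold lower number from compound 1 to compound 3 (0.30 log units; within the scatter), the first reading of any change on the aryl ring. At this aromatic carbon, para to a large group and meta to a chloro group, methyl can therefore take the place of chloro with no difference beyond the scatter. The same pair shows that this position tolerates either group while the long chain and the other chloro group stay fixed, and no measurement at hand bears on why the two groups read alike.

The compounds shown leave open how this position would read with other groups, such as methoxy, trifluoromethyl, an amine or a carboxylic acid, and whether the remaining chloro group can be replaced or removed. They also leave open whether the same exchange would read alike on the shorter chain of compound 2, and where a chain longer than that of compound 1 would fall.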